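The source may hold more compounds than are shown below. What is called first, only, known or untested is meant among the compounds shown, and "the series" means these compounds.

Going by the values given here, in an ADME assay on HEL cells (Homo sapiens) for cytotoxicity (on this read-out lower numbers stand for higher toxicity in this test and higher numbers for lower toxicity in this test), compound 2 `Cc1ccc(-[n+]2noc([O-])c2CN2CCN(c3cccc(Cl)c3Cl)CC2)cc1` gives 20 ug/mL, the lowest of the two numbers known here; compound 1 `Cc1ccc(-[n+]2noc([O-])c2CN2CCN(C)CC2)cc1` gives 100 ug/mL. Among the compounds with values here, the only measured step, a 5.0-fold lower number from compound 1 to compound 2 (0.70 log units; beyond the scatter), put the 2,3-dichlorophenyl in place of a methyl. Compound 3 `CC(=O)N1CCN(Cc2c([O-])on[n+]2-c2ccc(C)cc2)CC1` now removes that same group: acetyl in place of 2,3-dichlorophenyl on an amine nitrogen in a ring. Going by these compounds, that step is the one that bears on this change, and since it is reversed here, the number is expected to move back up, roughly by a 3.5-fold higher number from compound 2 to compound 3 (0.54 log units; beyond the scatter), though how the acetyl itself behaves is unknown. Compound 3 is estimated at 70 ug/mL, between 25 ug/mL and 200 ug/mL.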

Compound 3, minimum cytotoxic concentration: 100 ug/mL
Estimate against measurement, compound 3: 1.4-fold (0.15 log units) below, and the stated range covers the measured number.
By their numbers in this assay, from the lowest: compound 2; then compounds 1 and 3 (each within the scatter of the next).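

In this assay, acetyl in place of 2,3-dichlorophenyl gives a 5.0-fold higher number from compound 2 to compound 3 (0.70 log units; beyond the scatter), so the lower number seen with the 2,3-dichlorophenyl does not persist when that group leaves. Acetyl and methyl on this ring nitrogen read alike, with no change at the digits printed from compound 1 to compound 3 (within the scatter), so among these three groups only the 2,3-dichlorophenyl stands apart. No measurement here explains this difference. The compounds shown leave open whether the aromatic ring or its two chlorine atoms go with the lower number. A plain phenyl on the same nitrogen would help separate the two.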